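Swapping the bromophenyl arm for a hydroxyethyl chain

The source may hold more compounds than are shown below. What is called first, only, known or untested is meant among the compounds shown, and "the series" means these compounds.

In a functional assay on SW-620 cells (Homo sapiens) for antiproliferative activity, read by MTT assay, with a stated time of 72 h (on this read-out higher numbers stand for weaker inhibition and lower numbers for stronger inhibition), the three measured compounds read as follows:

Compound 1, `O=C1O[C@H]([C@@H](O)Cn2cc(-c3ccc(Br)cc3)nn2)C(OCc2ccccc2)=C1OCc1ccccc1`: 3760 nM
Compound 2, `O=C1O[C@H]([C@@H](O)Cn2cc(CNS(=O)(=O)c3ccc(F)cc3)nn2)C(OCc2ccccc2)=C1OCc1ccccc1`: 41100 nM
Compound 3, `O=C1O[C@H]([C@@H](O)Cn2ccnn2)C(OCc2ccccc2)=C1OCc1ccccc1`: > 100000 nM, a limit of the assay rather than a number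

Compound 1 holds the lowest of the two real numbers. Compound 3 sits at the limit, (the limit of > 100000 nM in this assay, at which 1 of the 3 values shown sits). Compound 4, `O=C1O[C@H]([C@@H](O)Cn2cc(CCO)nn2)C(OCc2ccccc2)=C1OCc1ccccc1`, is not yet measured and differs from compound 1 by 2-hydroxyethyl in place of 4-bromophenyl on an aromatic carbon. Among the compounds with values here, two measured steps bear on this change: an 11-fold higher number from compound 1 to compound 2 (1.04 log units; beyond the scatter) and an at least 26-fold higher number from compound 1 to compound 3 (1.42 log units; beyond the scatter), both large rises once the 4-bromophenyl is replaced or removed. A 2-hydroxyethyl in its place is therefore expected to bring a large rise in this assay as well, roughly a 16-fold higher number from compound 1 to compound 4 (1.20 log units; beyond the scatter). Compound 4 is estimated at 60000 nM, within 15000 nM to 150000 nM.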

Compound 4, half-maximal inhibitory concentration: > 100000 nM
Compound 4 was reported as a limit; the forecaster's own chance of this, stated with the estimate: 45%; middle value at least 1.6-fold (0.22 log units) away from the limit.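

In this assay, a 2-hydroxyethyl does not stand in for the 4-bromophenyl on this aromatic carbon: the change gives an at least 26-fold higher number from compound 1 to compound 4 (1.42 log units; beyond the scatter), and the sulfonamide arm also compares unfavourably, with an at least 2.4-fold higher number from compound 2 to compound 4 (0.38 log units; beyond the scatter). Compound 4 is reported only as a limit, and so is compound 3: the limit of > 100000 nM in this assay, at which 2 of the 4 values shown sit. The step between those two compounds cannot be read.

As far as these compounds go, it remains open whether the ring or the bromine matters more, which a plain phenyl at this carbon could separate. From the compounds shown here alone, how an amine at the end of the chain would read also remains open.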